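The source may report more compounds than this note shows. Statements on the series, on what has been measured and on what is new or still open speak of the compounds shown alone.

Measured compounds in a functional assay on SGC-7901 cells (Homo sapiens) for cytotoxicity, read by MTT assay, with a stated time of 48 h; on this read-out lower numbers stand for stronger inhibition and higher numbers for weaker inhibition:
Compound 1, `Cc1ncc([N+](=O)[O-])n1CCSc1nnc(-c2ccccc2)o1`: 30100 nM
Compound 2, `COc1ccccc1-c1nnc(SCCn2c([N+](=O)[O-])cnc2C)o1`: 30500 nM
Compound 3, `Cc1ncc([N+](=O)[O-])n1CCSc1nnc(-c2ccccc2Cl)o1`: 32600 nM

Compound 2 gives the second highest of the three numbers in this assay, but its nearest neighbour is compound 1 at a 1.0-fold higher number from compound 1 to compound 2 (0.01 log units; within the scatter) and the furthest is compound 3 at a 1.1-fold higher number from compound 2 to compound 3 (0.03 log units; within the scatter), so all three values sit within the scatter of one another and no order among them can be read.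

Compound 4, `Cc1ncc([N+](=O)[O-])n1CCSc1nnc(-c2ccccc2O)o1`, differs from compound 2 by hydrogen in place of methyl on an oxygen on an aromatic ring; cut one bond further out, the change reads methoxy to hydroxy. Going by the values given here, no measured step involves hydroxy. The steps that touch the same position are the entry of methoxy, a 1.0-fold higher number from compound 1 to compound 2 (0.01 log units; within the scatter), and the exchange of chloro for methoxy, a 1.1-fold higher number from compound 2 to compound 3 (0.03 log units; within the scatter), and the further step a 1.1-fold higher number from compound 1 to compound 3 (0.03 log units; within the scatter) likewise stays within the scatter. Among the compounds with values here, every change at this place so far has left the number where it was.

On that basis the step of a 1.0-fold lower number from compound 2 to compound 4 (0.01 log units; within the scatter) is expected to be nothing beyond the scatter. Compound 4 is therefore estimated at 30000 nM in this assay, with a range from 14000 nM to 65000 nM.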

Compound 4, half-maximal inhibitory concentration: 30500 nM
Estimate against measurement, compound 4: 1.0-fold (0.01 log units) below; low and high end bracket the measured number.
By their numbers in this assay, from the lowest: compounds 1, 2, 4 and 3 (each within the scatter of the next).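

In this assay, going by these compounds alone, removing the methyl from the oxygen of the 2-methoxyphenyl group gives no change at the digits printed from compound 2 to compound 4 (within the scatter), so this exchange, which no earlier pair covered, leaves the number where methoxy had it. Hydroxy also stands level with the other groups tried at this place: its exchange for chloro gives a 1.1-fold lower number from compound 3 to compound 4 (0.03 log units; within the scatter), and its entry in place of hydrogen gives a 1.0-fold higher number from compound 1 to compound 4 (0.01 log units; within the scatter). Hydrogen, methoxy, chloro and hydroxy therefore cannot be told apart at this place across these four compounds, and no information is available on the reason for this flat result.

The compounds shown leave open whether the number would stay the same with an amine or a carboxylic acid at this place, or with a longer chain such as ethoxy in place of methoxy. They also leave open whether these same groups would have as little effect on other carbons of that aromatic ring, and whether a change elsewhere in the shared core would move the number at all.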